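A few compounds are considered here, and "the series" means these few. Any claim that something is new, unique, unknown or untested is made for them only; others in the source may bear on it.

Working notes on the series. Three compounds carry numbers in an ADME assay on microsomes from liver (Homo sapiens) for metabolic stability, read by LC-MS, using NADPH, with stated times of 5 min and 30 min, tested at 1 uM; on this read-out higher numbers stand for fast clearance and lower numbers for slow clearance. Compound 1 `CN(c1ccn(C)n1)c1cnc(NCc2c(F)ccc3c2CCO3)c2cn[nH]c(=O)c12` gives 62 mL.min-1.g-1 in this assay. Compound 2 `Cc1ncccc1-c1cnc(NCc2c(F)ccc3c2CCO3)c2n[nH]c(=O)n12` gives 8 mL.min-1.g-1, and compound 3 `CN(c1ncco1)c1cnc(NCc2c(F)ccc3c2CCO3)n2cnnc12` gives 11 mL.min-1.g-1. Within the data shown here, compound 1 therefore stands highest of the three, and its gaps to compound 3 and to compound 2 both lie beyond the usual scatter, so compound 1 is the fastest-cleared compound measured so far.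

Compound 4 `Cc1nc(CO)ccc1-c1cnc(NCc2c(F)ccc3c2CCO3)c2cn[nH]c(=O)c12` has not yet been measured in this assay. It differs from compound 1 in one place: 6-(hydroxymethyl)-2-methylpyridin-3-yl in place of methyl(1-methyl-1H-pyrazol-3-yl)amino on an aromatic carbon. Among the measured compounds shown here, no measured pair shows this change on the shared core, and compounds 2 and 3 are built on other cores, so they only show that considerably lower numbers are reached within this set. For compound 4 a downward step from the value of compound 1 is expected, a 2.5-fold lower number from compound 1 to compound 4 (0.39 log units; beyond the scatter), of a size that should exceed the scatter but that remains uncertain without a matched pair. Compound 4 is accordingly estimated at 25 mL.min-1.g-1, with a plausible range from 10 mL.min-1.g-1 to 60 mL.min-1.g-1.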

Compound 4, intrinsic clearance in microsomes: 11 mL.min-1.g-1
The estimate for compound 4 lay 2.3-fold (0.36 log units) above the measured number; the range from low to high includes it.
By their numbers in this assay, from the lowest: compounds 2, 3 and 4 (each within the scatter of the next); then compound 1.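

Among these compounds, on the shared core, this position proves able to shift the read-out in this assay: 6-(hydroxymethyl)-2-methylpyridin-3-yl in place of methyl(1-methyl-1H-pyrazol-3-yl)amino gives a 5.6-fold lower number from compound 1 to compound 4 (0.75 log units; beyond the scatter) as the first step that can be read from a matched pair. The high number of compound 1 is therefore not fixed by the shared core alone, but depends on the group at this aromatic carbon. Nothing measured on these compounds accounts for the step. 

The change replaces the whole group at once, so the compounds shown do not separate any share of the hydroxymethyl, the methyl or the pyridine ring in this step. Also open, on these data alone, is whether an amine or a carboxylic acid in place of the hydroxymethyl would keep the lower number.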